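Working notes: methoxy to allyloxy at compound 4

A few compounds are considered here, and "the series" means these few. Any claim that something is new, unique, unknown or untested is made for them only; others in the source may bear on it.

compound 1 `COc1cccc(/C=C/C(=O)Nc2cc(OC)c(OC)c(OC)c2)c1`: 11300 nM
compound 2 `COc1ccccc1/C=C/C(=O)Nc1cc(OC)c(OC)c(OC)c1`: 6100 nM
compound 3 `COc1cc(NC(=O)/C=C/c2ccc(O)cc2)cc(OC)c1OC`: > 50000 nM, a limit of the assay

Among the compounds with values here, in a functional assay on HeLa cells (Homo sapiens) for cytotoxicity, read by sulforhodamine B assay, with a stated time of 72 h (a lower number here means a stronger inhibitor, a higher number a weaker inhibitor), compound 1 holds one of only two true numbers, and these two lie within the scatter: a 1.9-fold lower number from compound 1 to compound 2 (0.27 log units; within the scatter). Compound 4 `C=CCOc1cccc(/C=C/C(=O)Nc2cc(OC)c(OC)c(OC)c2)c1` changes methoxy to allyloxy on the core of compound 1: vinyl in place of hydrogen on a saturated chain carbon bound to an oxygen on an aromatic ring. Within the data shown here, no measured step alters that ether chain. Among the measured compounds shown here, the only steps beyond the scatter lead to the 4-hydroxyphenyl group: an at least 4.4-fold higher number from compound 1 to compound 3 (0.64 log units; beyond the scatter) and an at least 8.1-fold higher number from compound 2 to compound 3 (0.91 log units; beyond the scatter). Compound 4 lacks that group, and no step beyond the scatter is expected, with no firm direction: the estimate is a 1.1-fold lower number from compound 1 to compound 4 (0.05 log units; within the scatter). For compound 4 the estimated value is 10000 nM, with an expected range of 3500 nM to 30000 nM.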

Compound 4, half-maximal inhibitory concentration: 5400 nM
Estimate against measurement, compound 4: 1.9-fold (0.27 log units) above, and the stated range covers the measured number.
By their numbers in this assay, from the lowest: compounds 4, 2 and 1 (each within the scatter of the next, the first and the last beyond it). At a limit, above all of these: compound 3.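

In this assay, the ether chain on the core of compound 1 responds to change: methoxy to allyloxy gives a 2.1-fold lower number from compound 1 to compound 4 (0.32 log units; beyond the scatter), a modest step. Within the data shown here, it is the one step beyond the scatter that does not lead to the 4-hydroxyphenyl group, and it shows that vinyl is accepted on the saturated chain carbon bound to an oxygen on an aromatic ring. Nothing at hand accounts for this step.

Open: whether the step belongs to the double bond or to chain length, which a propyl ether would separate. Also open, as far as these compounds go, is how an amine on this chain would read.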